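The compounds below may be only part of what the source reports. "The series", "measured", "known", "first", "only" and "open" are said of these compounds alone.

Measured compounds:
- compound 1 `COc1cc(C)cc(-c2c(-c3ccnc(-c4ccc(N(C)C)cc4)c3)cnn2CC#N)c1`: 98%
- compound 2 `COc1cc(C)cc(-c2nn(CC#N)cc2-c2ccc(-c3cccc(C(C)=O)c3)nc2)c1`: 103%
- compound 3 `Cc1cc(O)cc(-c2nn(CC#N)cc2-c2ccnc(-c3ccc(N(C)C)cc3)c2)c1`: 109%

In a functional assay on COLO 205 cells (Homo sapiens) for cytotoxicity, read by sulforhodamine B assay, with a stated time of 48 h, tested at 0.001 uM (on this read-out lower numbers stand for a stronger effect and higher numbers for a weaker effect at the one concentration tested), compound 1 gives 98%, the lowest of the three numbers. Compound 2 lies within the usual scatter of it, so the two cannot be told apart; compound 3 stands beyond the scatter, above compound 1. All three numbers sit near full activity at the single concentration tested, so none of the compounds shows a marked effect in this assay.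

The step to compound 4 `COc1cc(C)cc(-c2c(-c3ccnc(-c4ccc(C(C)=O)cc4)c3)cnn2CC#N)c1` keeps the core of compound 1 and alters only one substituent: acetyl in place of dimethylamino on an aromatic carbon. Going by the values given here, no pair of measured compounds differs in a single place, so there is no measured step to draw on. Compound 2 carries an acetyl group elsewhere and gives 103%, close to compound 1.

Expectation: for compound 4 the change is expected to move the read-out little, in this assay no further than the scatter, if anything slightly upward, a number 5 percentage points higher from compound 1 to compound 4 (within the scatter). Compound 4 is therefore estimated at 103%, within a range from 92% to 113%.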

Compound 4, a percentage reported as activity, at one concentration (the size of the read-out at that concentration, not a potency): 109%
Compound 4: middle estimate off by 6 percentage points, on the low side; measured number inside the range.
By their numbers in this assay, from the lowest: compounds 1, 2, 3 and 4 (each within the scatter of the next, the first and the last beyond it).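

In this assay, going by these compounds alone, acetyl in place of dimethylamino on the aromatic carbon para to a large group gives the first single-place step, which reads as a number 11 percentage points higher from compound 1 to compound 4 (beyond the scatter) and so marks a modest shift toward a weaker effect. This position therefore responds to the exchange, although the two groups match in heavy-atom count and hydrogen-bond acceptor count and neither carries a net charge, so these counts do not separate them. Nothing measured accounts for the shift.

Going by these compounds, it remains open whether a primary amine or a carboxylic acid in this place would stay with compound 1 or move with compound 4. A single concentration also leaves open whether this modest step would persist at other concentrations.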